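A few compounds are considered here, and "the series" means these few. Any claim that something is new, unique, unknown or untested is made for them only; others in the source may bear on it.

In an ADME assay on MDCK cells (Canis lupus familiaris) for cytotoxicity, read by microscopy, with a stated time of 48 h (a higher number here means that more compound is tolerated, a lower number that less compound is tolerated), compound 2 `C[C@H]1[C@H](NCc2ccoc2)C[C@H]2C[C@@H]1C2(C)C` gives > 100000 nM, which is a limit of the assay and not a number. That is all that is known of where compound 2 stands on this read-out. Compound 1 `CCc1csc(CN[C@@H]2C[C@H]3C[C@@H]([C@H]2C)C3(C)C)c1` gives 25000 nM in this assay, and compound 3 `C=C(C)c1csc(CN[C@@H]2C[C@H]3C[C@@H]([C@H]2C)C3(C)C)c1` gives 25000 nM. Going by the values given here, the only step between measured compounds that differ in one place, no change at the digits printed from compound 1 to compound 3 (within the scatter), concerns a substituent on an aromatic carbon and leaves the ring itself as it was; it does not cover the change now in question. The unmeasured compound 4 `Cc1csc(CN[C@@H]2C[C@H]3C[C@@H]([C@H]2C)C3(C)C)n1` differs from compound 2 as follows: 4-methyl-1,3-thiazol-2-yl in place of furan-3-yl on a saturated chain carbon bound to an amine nitrogen. Among the compounds with values here, no measured step covers an exchange of the ring on the saturated chain carbon bound to an amine nitrogen, so the size and direction of the step rest on the spread of the values alone. Compound 2 sits at the limit of > 100000 nM in this assay, at which 1 of the 3 values shown sits. Compound 1 and compound 3, which carry another ring on the saturated chain carbon bound to an amine nitrogen, both give numbers. The expectation for compound 4 is therefore a value between those marks, a step of an at least 2.0-fold lower number from compound 2 to compound 4 (0.30 log units; that floor lies within the scatter) from the limit, with a fair chance that this assay again reports only a limit. Compound 4 is expected at 50000 nM in this assay, within 20000 nM to 100000 nM.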

Compound 4, minimum cytotoxic concentration: > 100000 nM
Compound 4 gave a limit, no number; the forecaster's own chance of this, stated with the estimate: 35%; at least 2.0-fold (0.30 log units) between middle value and limit.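

In this assay compound 4 gives > 100000 nM, a limit and not a number. Compound 2 also stands at a limit, and no step can be read between compound 2 and compound 4. Still open, on these data alone, is whether 4-methyl-1,3-thiazol-2-yl in place of furan-3-yl changes the tolerated concentration at all.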